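Aryl swap at the ring-nitrogen-adjacent carbon of the quinoline core

The source may hold more compounds than are shown below. What is called first, only, known or untested is meant among the compounds shown, and "the series" means these compounds.

Three compounds on the shared core have been run in an ADME assay on CCD 19Lu cells (Homo sapiens) for antiproliferative activity, read by MTT assay, with a stated time of 24 h (a lower number here means a stronger inhibitor, a higher number a weaker inhibitor), so far. Compound 1 `Clc1ccc(-c2cc(-c3ccccc3)c3cc(Br)ccc3n2)cc1` gives 528000 nM in this assay; compound 2 `Brc1ccc2nc(C3CCCCC3)cc(-c3ccccc3)c2c1` gives 490000 nM; compound 3 `Brc1ccc2nc(-c3ccco3)cc(-c3ccccc3)c2c1` gives 631000 nM. Compound 3 carries the highest of the three numbers, yet its separation from the others is small: a 1.2-fold higher number from compound 1 to compound 3 (0.08 log units; within the scatter) and a 1.3-fold higher number from compound 2 to compound 3 (0.11 log units; within the scatter), and likewise a 1.1-fold lower number from compound 1 to compound 2 (0.03 log units; within the scatter). None of the three swaps at this position moves the number beyond the scatter, so on the present data the group on this aromatic carbon has shown no measurable influence on this assay.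

Compound 4 `Oc1ccc(-c2cc(-c3ccccc3)c3cc(Br)ccc3n2)cc1` continues the same series of exchanges: 4-hydroxyphenyl in place of furan-2-yl on an aromatic carbon. Among the compounds with values here, the step most directly comparable is the one from compound 1 to compound 3, where one six-membered aryl group was traded against the five-membered furan-2-yl, with the result a 1.2-fold higher number from compound 1 to compound 3 (0.08 log units; within the scatter); the reverse direction of that kind of exchange is what compound 4 represents. Given that all three measured steps at this carbon stayed within the scatter, no step beyond the scatter is expected here either, and the estimated step of a 1.1-fold lower number from compound 3 to compound 4 (0.04 log units; within the scatter) is taken as flat. Compound 4 is therefore expected to give about 580000 nM in this assay, with a plausible range from 300000 nM to 1150000 nM.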

Compound 4, half-maximal inhibitory concentration: 104000 nM
For compound 4 the middle estimate is 5.6-fold (0.75 log units) above the measured one; the measured number lies below the stated range.
By their numbers in this assay, from the lowest: compound 4; then compounds 2, 1 and 3 (each within the scatter of the next).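

In this assay this carbon no longer looks silent: the exchange gives a 6.1-fold lower number from compound 3 to compound 4 (0.78 log units; beyond the scatter) and a 4.7-fold lower number from compound 2 to compound 4 (0.67 log units; beyond the scatter) and also a 5.1-fold lower number from compound 1 to compound 4 (0.71 log units; beyond the scatter), all beyond the scatter, so compound 4 stands apart from compound 1, compound 2 and compound 3, whose mutual steps all stayed within it. The step from the 4-chlorophenyl compound is the sharpest of these comparisons, since the six-membered aromatic ring stays and only chloro gives way to hydroxy; a six-membered aromatic ring alone therefore does not accompany the lower number, and among these four compounds only compound 4 has a hydrogen-bond donor in the group on this carbon. No available evidence bears on what lies behind this step.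

The compounds shown leave open whether the lower number follows the hydroxy group specifically or any hydrogen-bond donor on the phenyl ring, a distinction that 4-methoxyphenyl and 4-aminophenyl groups at this carbon would address. They also leave open how much the placement of the hydroxy group on the phenyl ring matters, as a 3-hydroxyphenyl group would show.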